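The source may report more compounds than this note shows. Statements on the series, on what has been measured and on what is new or still open speak of the compounds shown alone.

Compounds measured in a functional assay on KYSE-70 cells for antiproliferative activity against KYSE-70 cell line (Homo sapiens), read by MTT assay, with a stated time of 72 h; on this read-out higher numbers stand for weaker inhibition and lower numbers for stronger inhibition:
Compound 1, `O=C(Nc1ccc(C(F)(F)F)cc1)c1cc(=O)[nH]c2cc(Br)ccc12`: > 20000 nM, a limit of the assay.
Compound 2, `O=C(Nc1cccc(F)c1)c1cc(=O)[nH]c2cc(F)ccc12`: > 20000 nM, a limit of the assay.
Compound 3, `O=C(Nc1cc(F)cc(F)c1)c1cc(=O)[nH]c2cc(F)ccc12`: > 20000 nM, a limit of the assay.

Among the measured compounds shown here, compound 2 stands at the limit in this assay, and every value shown sits at that same limit (the limit of > 20000 nM in this assay, at which 3 of the 3 values shown sit), so no compound is set apart from another. For the measured compounds named here, the only measured step, a step that the two limits leave unreadable from compound 2 to compound 3, runs between two limits and its size cannot be read. Compound 4, `O=C(Nc1cccc(F)c1)c1cc(=O)[nH]c2cc(-c3ccncc3)ccc12`, differs from compound 2 by pyridin-4-yl in place of fluoro on an aromatic carbon. Going by the values given here, no measured step bears on this change: the step from compound 2 to compound 3 is the only one recorded and it is unreadable. These data therefore give no basis for expecting a step of readable size in this assay in either direction, nor for expecting none, and the starting value is itself a limit. Compound 4 is expected at 15000 nM, between 2000 nM and 40000 nM, an estimated step of an at least 1.3-fold lower number from compound 2 to compound 4 (0.12 log units; that floor lies within the scatter), with a fair chance that this assay again reports only a limit.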

Compound 4, half-maximal inhibitory concentration: > 20000 nM
Compound 4: only a limit was reported (the forecaster's own chance of this, stated with the estimate: 55%); at least 1.3-fold (0.12 log units) between middle value and limit.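

Among the compounds shown here, no step from compound 2 to compound 4 can be read, as both values are limits of this assay and not numbers, and the new value joins the others: the limit of > 20000 nM in this assay, at which 4 of the 4 values shown sit.

The compounds shown leave open whether any change to the shared core alters the read-out, and how far each compound lies past that limit.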